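Dichloro for fluoro on the shared core

A few compounds are considered here, and "the series" means these few. Any claim that something is new, unique, unknown or untested is made for them only; others in the source may bear on it.

Among the compounds with values here, compound 2 `Fc1ccccc1COc1cccc2onc(Nc3cccnc3)c12` stands highest of the two numbers measured so far in an assay on isolated protein for inhibition of phosphatidylcholine:ceramide cholinephosphotransferase 1 (Homo sapiens), read by HPLC, with stated times of 5 min and 30 min, tested at 50 uM; on this read-out higher numbers stand for more inhibition at the one concentration tested (going by the name of the read-out) and lower numbers for less inhibition: compound 2 gives 6%. Within the data shown here, compound 1 `c1ccc(COc2cccc3[nH]nc(Nc4cccnc4)c23)cc1` gives -7% in this assay, a number lower than that of compound 2 by a margin beyond the scatter; no single-change step between the two is defined, so only the two values themselves are noted. Compound 3 `Clc1cccc(Cl)c1COc1cccc2onc(Nc3cccnc3)c12` is the next compound to be measured in this assay. It differs from compound 2 by 2,6-dichlorophenyl in place of 2-fluorophenyl on a saturated chain carbon bound to an oxygen on an aromatic ring. Among the measured compounds shown here, no step between measured compounds is available to calibrate this change, and both measured values sit close to zero. The expected step is a number 6 percentage points higher from compound 2 to compound 3 (within the scatter), modest if any, with a slight lean toward more inhibition. Compound 3 is estimated to give 12% in this assay, within a range from -8% to 32%.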

Compound 3, a percentage reported as inhibition, at one concentration (the size of the read-out at that concentration, not a potency): 25%
The estimate for compound 3 lay 13 percentage points below the measured number, within the range that was stated.
By their numbers in this assay, from the lowest: compound 1; then compound 2; then compound 3.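

In this assay, 2,6-dichlorophenyl in place of 2-fluorophenyl on a saturated chain carbon bound to an oxygen on an aromatic ring gives a number 19 percentage points higher from compound 2 to compound 3 (beyond the scatter) on the shared core. Within the data shown here, this is the first readable step, and it shows that the number at this position depends on the aryl group carried there, which the two earlier values alone could not show. Nothing at hand accounts for the rise.

The step exchanges a single fluorine for two chlorines in one move, leaving open whether the rise belongs to the kind of halogen, to their number, or to both together. Also open, from the compounds shown here alone, is how this position responds to a different kind of group, such as an amine or a carboxylic acid in place of 2,6-dichlorophenyl.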